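The source may report more compounds than this note shows. Statements on the series, on what has been measured and on what is new or still open speak of the compounds shown alone.

Three close relatives of one core have been tested so far. Compound 1 `CCCCNc1nnc(SCC(=O)N(Cc2cccc([N+](=O)[O-])c2)c2ccc(F)cc2)s1` gives 33.6% in an assay on isolated protein for inhibition of Amine oxidase [flavin-containing] A (Homo sapiens), read by fluorescence and Amplex Red, with a stated time of 30 min, tested at 0.1 uM; a lower number here means a weaker effect, a higher number a stronger effect of the compound at the concentration tested; compound 2 `CC(C)CNc1nnc(SCC(=O)N(Cc2cccc([N+](=O)[O-])c2)c2ccc(F)cc2)s1` gives 31.8%; compound 3 `C=CCNc1nnc(SCC(=O)N(Cc2cccc([N+](=O)[O-])c2)c2ccc(F)cc2)s1` gives 43.2%. Compound 3 holds the highest of the three numbers, with compound 1 nearest to it and compound 2 furthest: the step of a number 9.6 percentage points higher from compound 1 to compound 3 (within the scatter) stays within the scatter, whereas a number 11.4 percentage points higher from compound 2 to compound 3 (beyond the scatter) is beyond it, if modest. Between the first two, a number 1.8 percentage points lower from compound 1 to compound 2 (within the scatter) shows no real separation.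

Compound 4 `CC(C)Nc1nnc(SCC(=O)N(Cc2cccc([N+](=O)[O-])c2)c2ccc(F)cc2)s1` is not yet measured. It differs from compound 3 as follows: isopropyl in place of allyl on a nitrogen on an aromatic ring. This change bears on the same place as the two steps that lead into compound 3, and it runs them backwards, taking away the group that goes with the highest number. Since the branched chain of compound 2 and the straight chain of compound 1 sit together, a fall back toward their level is expected for compound 4, meaning a step of a number 11.2 percentage points lower from compound 3 to compound 4 (beyond the scatter). Compound 4 is therefore estimated at 32%, within the range 22% to 42%.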

Compound 4, a percentage reported as inhibition, at one concentration (the size of the read-out at that concentration, not a potency): 43%
Compound 4: the middle estimate sits 11 percentage points below what was measured, outside the stated range (above it).
By their numbers in this assay, from the lowest: compounds 2, 1, 4 and 3 (each within the scatter of the next, the first and the last beyond it).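

The step of a number 0.2 percentage points lower from compound 3 to compound 4 (within the scatter) in this assay shows that allyl and isopropyl on this nitrogen cannot be told apart, so the double bond of allyl is not needed to reach this level. Isopropyl stands clear of isobutyl in the step of a number 11.2 percentage points higher from compound 2 to compound 4 (beyond the scatter) but not of butyl in the step of a number 9.4 percentage points higher from compound 1 to compound 4 (within the scatter) and so compound 1 goes against any rule that the two groups of 3 carbons outdo both butyl and isobutyl. Nothing available explains these numbers.

From the compounds shown here alone, whether methyl, ethyl, cyclopropyl or a chain ending in an amine on this nitrogen would hold, raise or lower the number stays open. Each compound also has a read-out at only one concentration, so these numbers tell only of a stronger or weaker effect at that concentration.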